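The source may hold more compounds than are shown below. What is called first, only, known or untested is meant among the compounds shown, and "the series" means these compounds.

In an ADME assay on BHK-21 cells (Mesocricetus auratus) for cytotoxicity, read by MTT assay, with a stated time of 72 h (a lower number here means that less compound is tolerated, a higher number that more compound is tolerated), compound 3 (`Cc1ccc(NCc2cn(-c3ccccc3)nc2-c2ccccc2)cc1`) gives > 100000 nM as its reading, which is a limit and not a number. Compound 1 (`Brc1ccc(NCc2cn(-c3ccccc3)nc2-c2ccccc2)cc1`) gives > 100000 nM as its reading, which is also a limit. The position of compound 3 is thus the limit of > 100000 nM in this assay, at which 2 of the 3 values shown sit, with no exact number to start from.

The next compound to be tested is compound 4 (`FC(F)(F)c1ccc(NCc2cn(-c3ccccc3)nc2-c2ccccc2)cc1`). The change from compound 3 is trifluoromethyl in place of methyl on an aromatic carbon and, in plain terms, it puts trifluoromethyl in place of methyl on an aromatic carbon. Among the measured compounds shown here, the only measured step at this place is a step that the two limits leave unreadable from compound 1 to compound 3 and it offers no size to carry over.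

The nearest guide is compound 2 (`FC(F)(F)c1ccc(NCc2cn(-c3ccccc3)nc2-c2ccc(C(F)(F)F)cc2)cc1`), which holds this same trifluoromethyl along with a second trifluoromethyl elsewhere on the shared core. Compound 2 gives 27000 nM as a true number in this assay and so serves as a measured point of reference. A moderate move toward a lower number, meaning somewhat less compound tolerated, is therefore expected, though a reading that stays at the limit remains possible. The expected size is an at least 1.4-fold lower number from compound 3 to compound 4 (0.15 log units; that floor lies within the scatter) as an estimate. For compound 4 the estimated value is 70000 nM with an expected range from 30000 nM to 100000 nM as its likely span.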

Compound 4, half-maximal cytotoxic concentration: 37000 nM
The estimate for compound 4 lay 1.9-fold (0.28 log units) above the measured number; low and high end bracket the measured number.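

In this assay, among the compounds shown here, trifluoromethyl on this aromatic carbon, para to a large group, is the first change at this place with a readable size: putting it in place of methyl gives an at least 2.7-fold lower number from compound 3 to compound 4 (0.43 log units; beyond the scatter), and putting it in place of bromo gives an at least 2.7-fold lower number from compound 1 to compound 4 (0.43 log units; beyond the scatter). The other trifluoromethyl in compound 2 adds nothing that can be read, as hydrogen in its place gives a 1.4-fold higher number from compound 2 to compound 4 (0.14 log units; within the scatter), so a single trifluoromethyl at this place is enough for an exact number to appear in this small set. The two larger steps are only floors, as the readings of compound 1 and compound 3 are limits and not numbers: the limit of > 100000 nM in this assay, at which 2 of the 4 values shown sit.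

The compounds shown leave open how far the tolerated amount really falls when methyl or bromo gives way to trifluoromethyl, and whether this place responds to trifluoromethyl alone. A nitrile, a methoxy group, an amine or a carboxylic acid at the same aromatic carbon could show whether the reading stays at the limit or moves to a measurable number.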